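Removing a Ring Hydroxy From a Weakly Cytotoxic Ester

The compounds below may be only part of what the source reports. "The series", "measured", "known", "first", "only" and "open" are said of these compounds alone.

Compound 1, `CC1=CC[C@]2(C)[C@@H]([C@@H](OC(=O)c3ccc(O)cc3)C1)[C@](O)(C(C)C)C[C@@H]2O`: 56500 nM
Compound 2, `C=C1C[C@H](OC(=O)c2ccc(O)cc2)[C@@H]2[C@](C)(CC[C@@]2(O)C(C)C)C[C@@H]1O`: > 100000 nM

For the measured compounds named here, in a functional assay on HeLa cells (Homo sapiens) for cytotoxicity, read by MTT assay, with a stated time of 72 h (on this read-out lower numbers stand for stronger inhibition and higher numbers for weaker inhibition), compound 1 gives 56500 nM, the only plain number among the two values shown. For compound 2 the read-out is > 100000 nM, which is a limit of the assay rather than a number (the limit of > 100000 nM in this assay, at which 1 of the 2 values shown sits). Compound 3, `CC1=CC[C@@]2(C)CC[C@@](O)(C(C)C)[C@@H]2[C@@H](OC(=O)c2ccc(O)cc2)C1`, has not yet been measured; it differs from compound 1 by hydrogen in place of hydroxy on a saturated ring carbon. Going by the values given here, no step between measured compounds is available to gauge a change of this kind, so the expectation for compound 3 rests on the value of compound 1 alone, 56500 nM. The step of a 1.2-fold higher number from compound 1 to compound 3 (0.09 log units; within the scatter) is expected to be modest and not clearly beyond the usual scatter, in no settled direction. Compound 3 is therefore estimated in this assay at 70000 nM, within a range from 25000 nM to 200000 nM, with a real chance that only a limit is returned.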

Compound 3, half-maximal inhibitory concentration: > 100000 nM
Compound 3 gave a limit, no number; the forecaster's own chance of this, stated with the estimate: 40%; middle value at least 1.4-fold (0.15 log units) from the limit.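

For the compounds shown here, the first reading at this position in this assay is an at least 1.7-fold higher number from compound 1 to compound 3 (0.24 log units; that floor lies within the scatter), for hydrogen in place of hydroxy on a saturated ring carbon of the five-membered ring. From the compounds shown here alone, that figure is only a floor, so the true size of the step stays unknown, but the change gives no sign of stronger inhibition. Compound 3 also gives a limit of the assay rather than a number: the limit of > 100000 nM in this assay, at which 2 of the 3 values shown sit.

Going by these compounds, whether another group on this carbon, such as an amine or a methoxy group, would give a lower number than compound 1 remains open. Also open, on these data alone, is whether the loss of the hydroxy truly moves the read-out beyond the usual scatter.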